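A vinyl group added to the chain of compound 2

The compounds below may be only part of what the source reports. "The series", "measured", "known", "first", "only" and "open" are said of these compounds alone.

- compound 1 `Cn1c2cnc1OCCCCCCCCCCOc1ccccc1-2` gives 33000 nM
- compound 2 `CCCCOc1ncc(-c2ccccc2OC)n1C` gives 39000 nM

In a functional assay on LoVo cells (Homo sapiens) for inhibition, read by colorimetric assay and MTT assay, with a stated time of 72 h (on this read-out higher numbers stand for weaker inhibition and lower numbers for stronger inhibition), compound 2 stands at 39000 nM and compound 1 at 33000 nM and these two values lie within the usual scatter of each other. Compound 3 `C=CCCCCOc1ncc(-c2ccccc2OC)n1C` differs from compound 2 by vinyl in place of hydrogen on a saturated chain carbon, four bonds along the chain from an oxygen on an aromatic ring with vinyl in place of hydrogen on a saturated chain carbon, four bonds along the chain from an oxygen on an aromatic ring. Going by the values given here, no measured pair shows such a change, so only a small step toward a lower number, or none beyond the scatter, is expected. The expected step is a 1.3-fold lower number from compound 2 to compound 3 (0.11 log units; within the scatter) in this estimate. For compound 3 the estimated value is 30000 nM with an expected range from 12000 nM to 70000 nM as the likely span.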

Compound 3, half-maximal inhibitory concentration: 4000 nM
The estimate for compound 3 lay 7.5-fold (0.88 log units) above the measured number; the measured number lies below the stated range.
By their numbers in this assay, from the lowest: compound 3; then compounds 1 and 2 (each within the scatter of the next).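

In this assay, putting vinyl in place of hydrogen on a saturated chain carbon, four bonds along the chain from an oxygen on an aromatic ring, gives a 9.8-fold lower number from compound 2 to compound 3 (0.99 log units; beyond the scatter) and so shows that this place on the chain responds to what is attached there. Going by these compounds alone, the earlier compounds offered no step at this place, so this is the first sign of that. Nothing available here explains the size of this step.

Going by these compounds, whether the double bond matters, or the added carbons alone would do the same, remains open. A plain hexyl chain would separate those two readings, and an amine at the chain's end would test how far other groups are accepted.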